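A few compounds are considered here, and "the series" means these few. Any claim that something is new, unique, unknown or untested is made for them only; others in the source may bear on it.

Three compounds have been measured in a functional assay on RAW264.7 cells (Mus musculus) for inhibition, read by ELISA, with a stated time of 24 h; on this read-out lower numbers stand for an effect already at smaller amounts and higher numbers for an effect only at larger amounts of compound:

Compound 1, `CC/C=C\C[C@H]1C(=O)C=C[C@H]1CC(=O)OCCCC`: 23000 nM
Compound 2, `CC/C=C\C[C@H]1C(=O)C=C[C@H]1CC(=O)Oc1ccccc1`: 33000 nM
Compound 3, `CC/C=C\C[C@H]1C(=O)C=C[C@H]1CC(=O)OCCOCCOC`: 33000 nM

All three share one core and differ only in the group on the oxygen next to the ester carbonyl. Compound 2, the phenyl ester, gives a number level with that of compound 3, and the step of a 1.4-fold higher number from compound 1 to compound 2 (0.16 log units; within the scatter) shows that compound 2 is not separated from compound 1 by more than the usual scatter either; the three numbers are in effect indistinguishable.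

Compound 4, `CC/C=C\C[C@H]1C(=O)C=C[C@H]1CC(=O)OC(C)CC`, is the next compound to be measured. Relative to compound 2 the change is sec-butyl in place of phenyl on an oxygen next to a carbonyl group.

Going by the values given here, two measured steps bear on this. The step of a 1.4-fold higher number from compound 1 to compound 2 (0.16 log units; within the scatter) exchanges an alkyl chain for phenyl at the same oxygen and stays within the scatter, and the step of no change at the digits printed from compound 2 to compound 3 (within the scatter) exchanges phenyl for a saturated chain at that oxygen and shows no change at all. Compound 4 is itself an alkyl ester, closer to compound 1 than to compound 2 in what sits on that oxygen. The expectation is therefore a step of a 1.3-fold lower number from compound 2 to compound 4 (0.12 log units; within the scatter), that is nothing beyond the scatter.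

Compound 4 is accordingly estimated at 25000 nM, with a range from 12000 nM to 55000 nM.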

Compound 4, half-maximal effective concentration: 22000 nM
Compound 4: middle estimate off by 1.1-fold (0.06 log units), on the high side, and the stated range covers the measured number.
By their numbers in this assay, from the lowest: compounds 4, 1, 2 and 3 (each within the scatter of the next).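

Sec-butyl in place of butyl is the smallest change yet on the oxygen next to a carbonyl group, and in this assay it gives a 1.0-fold lower number from compound 1 to compound 4 (0.02 log units; within the scatter) and so stays within the scatter. Taking sec-butyl against the two other groups gives a 1.5-fold lower number from compound 2 to compound 4 (0.18 log units; within the scatter) and a 1.5-fold lower number from compound 3 to compound 4 (0.18 log units; within the scatter) and both also stay within the scatter, so the four esters, carrying butyl, phenyl, 2-(2-methoxyethoxy)ethyl and sec-butyl, cannot be told apart in this assay and this position has so far shown no response to the exchange of one of these groups for another. Nothing available explains why such different groups give such similar numbers.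

The compounds shown leave open whether any other change here would produce a step beyond the scatter, for example a carboxylic acid or an amide in place of the ester, or an amine or a much longer chain such as dodecyl on this oxygen. On these data alone, all four also share one core, so what a change elsewhere in that core would do remains open too.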